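Receptor antagonists: notes

The source may report more compounds than this note shows. Statements on the series, on what has been measured and on what is new or still open speak of the compounds shown alone.

Compound 2 `COc1ccccc1CN1CC(=O)N(c2cnn(Cc3c(C)noc3C)c2)C1=O` stands at the lower of the two numbers in hand: in a functional assay on cells for antagonist activity at taste receptor type 2 member 8 (Homo sapiens), read by FLIPR and calcium flux, with a stated time of 100 s (a lower number here means a stronger inhibitor, a higher number a weaker inhibitor), compound 2 gives 100 nM. For the measured compounds named here, compound 1 `Cc1noc(C)c1Cn1cc(NC(=O)c2ccc(O)cc2)cn1` differs from compound 2 in more than one place, so no single step connects the pair; in this assay compound 1 gives 500 nM, and the gap between these two numbers lies beyond the scatter of repeated measurement. The next compound keeps the core of compound 2 and alters only the group on the saturated chain carbon bound to an amide-type nitrogen in a ring. Going by the values given here, compound 3 `Cc1cc(CN2CC(=O)N(c3cnn(Cc4c(C)noc4C)c3)C2=O)n(C)n1` carries 1,3-dimethyl-1H-pyrazol-5-yl where compound 2 carries 2-methoxyphenyl: 1,3-dimethyl-1H-pyrazol-5-yl in place of 2-methoxyphenyl on a saturated chain carbon bound to an amide-type nitrogen in a ring No measured pair shows what this kind of exchange does, and there is no other comparison of a five-membered aromatic ring with 2 hetero atoms against a six-membered aromatic ring of carbon only. With nothing to anchor the direction, the expectation is a step within or just beyond the scatter, leaning toward a somewhat higher number for compound 3. The step expected from compound 2 to compound 3 is a 2.0-fold higher number from compound 2 to compound 3 (0.30 log units; within the scatter). In this assay compound 3 is estimated at 200 nM, with a range from 60 nM to 700 nM.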

Compound 3, half-maximal inhibitory concentration: 200 nM
Compound 3: middle estimate and measured number agree at the digits printed; low and high end bracket the measured number.
By their numbers in this assay, from the lowest: compounds 2 and 3 (each within the scatter of the next); then compound 1.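

At the saturated chain carbon bound to an amide-type nitrogen in a ring, 1,3-dimethyl-1H-pyrazol-5-yl in place of 2-methoxyphenyl gives a 2.0-fold higher number from compound 2 to compound 3 (0.30 log units; within the scatter) in this assay. For the compounds shown here, this is the first single-place comparison, and it shows that at this position a five-membered aromatic ring with 2 hetero atoms can stand in for a six-membered aromatic ring of carbon only, with the readout of the pair staying within the scatter, even though the entering group differs in its atoms and carries 2 hydrogen-bond acceptors against 1. Nothing available explains why the exchange reads this way.

The compounds shown leave open whether the methoxy group of 2-methoxyphenyl contributes anything, which plain phenyl would test, and whether the two methyl groups on the pyrazole contribute anything, which an unsubstituted pyrazole would test. Going by these compounds alone, also open is how this position responds to a group of a different kind, such as an amine, a carboxylic acid or a longer alkyl chain, and compound 1 remains linked to the others by no single step.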